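Cytotoxicity limits across a four-compound series

The source may report more compounds than this note shows. Statements on the series, on what has been measured and on what is new or still open speak of the compounds shown alone.

The set comprises compound 1 `Clc1ccc2c(NCCn3cnc4c(N5CCCCCC5)nc(Cl)nc43)ccnc2c1`, compound 2 `CN1CCN(c2nc(Cl)nc3c2ncn3CCNc2ccnc3cc(Cl)ccc23)CC1`, compound 3 `Clc1ccc2c(NCCCn3cnc4c(N5CCCCCC5)nc(Cl)nc43)ccnc2c1` and the still unmeasured compound 4 `CN1CCN(c2nc(Cl)nc3c2ncn3CCCNc2ccnc3cc(Cl)ccc23)CC1`. All are read in an ADME assay on Vero cells (Chlorocebus sabaeus) for cytotoxicity, read by neutral red uptake, with a stated time of 48 h; a lower number here means a stronger inhibitor, a higher number a weaker inhibitor.

In this assay compound 1 gives > 10400 nM, which is a limit of the assay. Compound 2 gives > 10400 nM in this assay, again a limit. Compound 3 gives > 10100 nM in this assay, also a limit.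

From compound 1 to compound 2 the change is 4-methylpiperazin-1-yl in place of azepan-1-yl on an aromatic carbon. The step is a step that the two limits leave unreadable from compound 1 to compound 2, unreadable since both compounds sit at the limit of > 10400 nM in this assay, at which 2 of the 3 values shown sit. The difference between the cores of compound 1 and compound 3 is not broken down here; their values show only two limits, with compound 3 standing at the limit of > 10100 nM in this assay, at which 1 of the 3 values shown sits.

Compound 4 carries the same change on the core of compound 3: 4-methylpiperazin-1-yl in place of azepan-1-yl on an aromatic carbon. The surroundings of the place read the same word for word in both pairs, so the change is the same, not merely the same kind.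

The step from compound 3 to compound 4 is expected to be a step that the limit leaves unreadable from compound 3 to compound 4 in this assay. This expectation rests on compound 1 and compound 2 both sitting at the limit of > 10400 nM in this assay, at which 2 of the 3 values shown sit, so the same change gave no readable step there. For compound 4 the estimated value in this assay is 15000 nM, most probably reported again only as a limit, with the expected range running from 8000 nM to 50000 nM.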

Compound 4, half-maximal inhibitory concentration: > 10100 nM
Compound 4 gave a limit, no number; the forecaster's own chance of this, stated with the estimate: 85%; the middle value lies beyond the limit too.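

No step can be read between compound 3 and compound 4: in this assay compound 4 gives > 10100 nM, a limit of the assay, as compound 3 also gives only a limit. The compounds shown leave open what actual half-maximal inhibitory concentration any of the four has in this assay, and whether 4-methylpiperazin-1-yl in place of azepan-1-yl changes it at all.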